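Amide in place of sulfonamide on the chemerin receptor core

A few compounds are considered here, and "the series" means these few. Any claim that something is new, unique, unknown or untested is made for them only; others in the source may bear on it.

Measured compounds:
- Compound 1 `CCCCN(c1nc2c(C(=O)O)cccc2o1)[C@H](C)c1ccc(-c2ccccc2-c2nnn[nH]2)cc1`; in a functional assay on CAL1 cells for inhibition of chemerin-like receptor 1 (Homo sapiens), with a stated time of 45 min (on this read-out higher numbers stand for weaker inhibition and lower numbers for stronger inhibition), compound 1 gives 17 nM.
- Compound 2 `C[C@H](c1ccc(-c2ccccc2-c2nc(=O)o[nH]2)cc1)N(CC1CC1)c1nc2c(C(=O)O)cccc2o1`; compound 2 gives 11 nM.
- Compound 3 `CCCCN(c1nc2c(NS(C)(=O)=O)cccc2o1)[C@H](C)c1ccc(-c2ccccc2-c2nnn[nH]2)cc1`; compound 3 gives 14 nM.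

Compound 3 stands second highest of the three numbers. Its nearest neighbour is compound 1, and the step of a 1.2-fold lower number from compound 1 to compound 3 (0.08 log units; within the scatter) shows that exchanging the carboxy group for methanesulfonamido left the number within the scatter. Compound 2, with a different amine substituent and a different acidic ring, is also within the scatter of compound 3, so the three values show no separation.

Compound 4 `CCCCN(c1nc2c(C(=O)NC)cccc2o1)[C@H](C)c1ccc(-c2ccccc2-c2nnn[nH]2)cc1` is not yet measured. The change from compound 3 is methylcarbamoyl in place of methanesulfonamido on an aromatic carbon. Among the measured compounds shown here, the only step that bears on this position, a 1.2-fold lower number from compound 1 to compound 3 (0.08 log units; within the scatter), was within the scatter, so a substituent exchange at this aromatic carbon has so far moved the number little. With one step as guide, the expected step of a 1.8-fold higher number from compound 3 to compound 4 (0.25 log units; within the scatter) is small, leaning toward a somewhat higher number. The estimate for compound 4 in this assay is 25 nM, with a range from 10 nM to 70 nM.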

Compound 4, half-maximal inhibitory concentration: 110 nM
For compound 4 the middle estimate is 4.4-fold (0.64 log units) below the measured one; measured number outside the range, above it.
By their numbers in this assay, from the lowest: compounds 2, 3 and 1 (each within the scatter of the next); then compound 4.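

In this assay, among the compounds shown here, this aromatic carbon turns out not to tolerate every substituent: methylcarbamoyl in place of methanesulfonamido gives a 7.9-fold higher number from compound 3 to compound 4 (0.90 log units; beyond the scatter) and is the first step at this position beyond the scatter. Methylamino in place of hydroxy on the carbonyl carbon gives a 6.5-fold higher number from compound 1 to compound 4 (0.81 log units; beyond the scatter), so turning the carboxy group into its methyl amide has a similar outcome. Carboxy and methanesulfonamido had stayed within the scatter of each other, and only compound 4 now shows that the number at this position can move.

Nothing shown here explains the higher number of compound 4. On these data alone, it remains open whether an unsubstituted carboxamide or an ethylcarbamoyl group at this carbon would stand near compound 4 or near compound 1.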